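The source may hold more compounds than are shown below. What is called first, only, known or untested is meant among the compounds shown, and "the series" means these compounds.

Compound 2 `C=C(C)C(=O)c1ccc(OCc2nc(-c3ccc([N+](=O)[O-])cc3)cs2)c(C)c1C` is tested in a functional assay on HL-60 cells (Homo sapiens) for inhibition, read by trypan blue exclusion, with a stated time of 72 h (on this read-out lower numbers stand for stronger inhibition of growth and higher numbers for weaker inhibition of growth), where compound 2 gives 5100 nM. Going by the values given here, of the two numbers so far this is the highest. Its nearest neighbour is compound 1 `C=C(CC)C(=O)c1ccc(OCc2nc(-c3ccc4ccccc4c3)cs2)c(C)c1C`, which in this assay gives 2000 nM, a lower number that lies beyond the usual scatter of the method. Among the compounds with values here, no single-point step between these two measured compounds can be drawn, since they differ in more than one place, so their two values are simply taken as they stand.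

Compound 3 `C=C(C)C(=O)c1ccc(OCc2nc(-c3ccc4ccccc4c3)cs2)c(C)c1C` has not yet been measured in this assay. It differs from compound 2 in one place: naphthalen-2-yl in place of 4-nitrophenyl on an aromatic carbon. Within the data shown here, compound 1 also carries naphthalen-2-yl and gives the lower of the two numbers, which is the only guide available for this change. On that basis compound 3 is expected to give a lower number than compound 2 in this assay, with the step expected to be a 2.0-fold lower number from compound 2 to compound 3 (0.31 log units; beyond the scatter), close to the edge of the scatter rather than a large shift. Compound 3 is estimated at 2500 nM, with a range from 1000 nM to 6000 nM.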

Compound 3, concentration for 50% growth inhibition: 2300 nM
Beside the measured number, compound 3's estimate is 1.1-fold (0.04 log units) above it; the range from low to high includes it.
By their numbers in this assay, from the lowest: compounds 1 and 3 (each within the scatter of the next); then compound 2.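

Going by these compounds alone, with compound 3, the group on the aromatic carbon next to the ring nitrogen can be read on its own for the first time: in this assay, naphthalen-2-yl in place of 4-nitrophenyl gives a 2.2-fold lower number from compound 2 to compound 3 (0.35 log units; beyond the scatter), a modest step but one beyond the scatter, so growth inhibition responds to the group at this position. The chain is also tested on its own, and hydrogen in place of methyl on the saturated chain carbon bound to the double-bonded chain carbon gives a 1.2-fold higher number from compound 1 to compound 3 (0.06 log units; within the scatter), which lies within the scatter, so this change has no readable effect in this assay. Nothing at hand offers an explanation for either step.

The compounds shown leave open whether the step at the aromatic carbon follows from the loss of the nitro group or from the entry of the two-ring naphthalen-2-yl group, a question that plain phenyl, 4-aminophenyl or naphthalen-1-yl at the same carbon could help to settle. They also leave open how a longer chain, such as propyl, would behave on the double-bonded chain carbon.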